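A few compounds are considered here, and "the series" means these few. Any claim that something is new, unique, unknown or untested is made for them only; others in the source may bear on it.

Of the compounds shown here, two of this small series have been tested in an ADME assay on HEL cells (Homo sapiens) for cytotoxicity, with a stated time of 3 days; on this read-out lower numbers stand for higher toxicity in this test and higher numbers for lower toxicity in this test. Compound 1 `Cc1cc(-n2ccc3cccnc32)cn2c(CSCCc3ccccc3)cnc12` gives 20 ug/mL. Compound 2 `Cc1cc(-c2ccoc2)c2ncc(CSCCc3ccccc3)n2c1` gives 100 ug/mL, the higher of the two numbers, which places it as the less toxic of the pair; compound 1 sits at a number lower by an amount beyond the usual scatter. Among the measured compounds shown here, the two differ in more than one place, so no single step between them can be read from their values alone.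

Compound 3 `Cc1cc(-n2ccc3cccnc32)c2ncc(CSCCc3ccccc3)n2c1` shares the core of compound 2 and carries instead the group found in compound 1. Set against compound 2, the change is a group of 9 heavy atoms (7 carbon, 2 nitrogen; one five-membered aromatic ring with 1 hetero atom, one six-membered aromatic ring with 1 hetero atom) in place of a group of 5 heavy atoms (4 carbon, 1 oxygen; one five-membered aromatic ring with 1 hetero atom), on an aromatic carbon.

Because compound 1, which carries this same entering group, gives 20 ug/mL, the step from compound 2 to compound 3 is expected to run toward higher toxicity, that is toward a lower number, probably by a margin beyond the scatter. The estimated step is a 3.3-fold lower number from compound 2 to compound 3 (0.52 log units; beyond the scatter). In this assay compound 3 is therefore expected to give about 30 ug/mL, with a likely range from 10 ug/mL to 100 ug/mL.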

Compound 3, minimum cytotoxic concentration: 100 ug/mL
Compound 3: the middle estimate sits 3.3-fold (0.52 log units) below what was measured; measured number inside the range.
By their numbers in this assay, from the lowest: compound 1; then compounds 2 and 3 (each within the scatter of the next).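

In this assay, swapping the furan-3-yl group for the larger two-ring group of 9 heavy atoms, on this aromatic carbon meta to a methyl group, gives no change at the digits printed from compound 2 to compound 3 (within the scatter). At this position of this core, then, the read-out tolerates a considerably larger group with an extra ring, and the two groups cannot be told apart in this test. The larger group also sits in compound 1, which gives 20 ug/mL on a different core, yet compound 3 carries it and gives 100 ug/mL, so the group alone does not bring the lower number of compound 1, and no measurement shown here explains why the swap leaves the read-out as it is.

As far as these compounds go, what remains open is whether a simple phenyl ring, an amine or a carboxylic acid at this same carbon would also leave the number in place, or would move it beyond the scatter. Equally open, from the compounds shown here alone, is whether the side chain with its sulfur and phenyl ring matters to the read-out, which a shorter or longer chain on the same core could test.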